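Swapping trifluoromethyl for methyl on a triazolothiadiazine series

The source may report more compounds than this note shows. Statements on the series, on what has been measured and on what is new or still open speak of the compounds shown alone.

Measured so far in a functional assay on HCT-116 cells (Homo sapiens) for inhibition, read by sulforhodamine B assay, with a stated time of 72 h; on this read-out higher numbers stand for weaker inhibition and lower numbers for stronger inhibition:
- compound 1 `CC(c1ccc(-c2ccccc2)c(F)c1)c1nnc2n1N=C(c1ccc(Cl)cc1)CS2`: 7800 nM
- compound 2 `CC(c1ccc(-c2ccccc2)c(F)c1)c1nnc2n1N=C(c1ccc(OC(F)(F)F)cc1)CS2`: 5400 nM
- compound 3 `COc1ccc2cc(C(C)c3nnc4n3N=C(c3ccc(C(F)(F)F)cc3)CS4)ccc2c1`: 10800 nM

Compound 3 has the highest number of the three, yet its gaps to compound 1 and compound 2 both lie within the scatter, so no order among them can be claimed. Compound 4 `COc1ccc2cc(C(C)c3nnc4n3N=C(c3ccc(C)cc3)CS4)ccc2c1` differs from compound 3 by methyl in place of trifluoromethyl on an aromatic carbon. For the measured compounds named here, the only step that bears on it is a 1.4-fold lower number from compound 1 to compound 2 (0.16 log units; within the scatter), another swap of the group on the same aromatic carbon, and it stayed within the scatter. Compound 4 is therefore expected to show no step beyond the scatter, a 1.1-fold lower number from compound 3 to compound 4 (0.03 log units; within the scatter), with an estimate of 10000 nM and a range from 4000 nM to 25000 nM.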

Compound 4, half-maximal inhibitory concentration: 10200 nM
For compound 4 the middle estimate is 1.0-fold (0.01 log units) below the measured one, and the stated range covers the measured number.
By their numbers in this assay, from the lowest: compounds 2, 1, 4 and 3 (each within the scatter of the next).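

In this assay, going from 4-(trifluoromethyl)phenyl to 4-methylphenyl gives a 1.1-fold lower number from compound 3 to compound 4 (0.02 log units; within the scatter), so removing all the fluorine from this group leaves no readable effect. The earlier swap on this aromatic carbon, trifluoromethoxy in place of chloro, was made with a different group elsewhere on the shared core, and this second swap also stays within the scatter. Nothing available explains this result. On these data alone, whether an amine or a carboxylic acid on this carbon would produce a step beyond the scatter remains open.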